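This account rests on a few compounds, and the source may have more. Where it says the series, first, only, none or still open, it means among the compounds named here.

Compound 1 `COc1cccc(NC(=O)c2nnn(Cc3cc(C)on3)c2N)c1` gives 2.6 mL.min-1.g-1 in an ADME assay on microsomes from liver (Mus musculus, strain CD1) for metabolic stability, read by HPLC, using NADPH, with a stated time of 30 min; a lower number here means slower removal, a higher number faster removal of the compound. Compound 3 `COc1cccc(NC(=O)c2nnn(Cc3ccccc3)c2N)c1` gives 3.7 mL.min-1.g-1 in this assay, and the step of a 1.4-fold higher number from compound 1 to compound 3 (0.15 log units; within the scatter) sits inside the usual scatter. Compound 2 `COc1cccc(NC(=O)c2nnn(CC3CCNCC3)c2N)c1` is reported in this assay only as a limit, < 0.5 mL.min-1.g-1, so its place on the numbers is open at the low side. The steps of an at least 5.2-fold lower number from compound 1 to compound 2 (0.71 log units; beyond the scatter) and an at least 7.4-fold higher number from compound 2 to compound 3 (0.86 log units; beyond the scatter) both end at the limit of < 0.5 mL.min-1.g-1 in this assay, at which 1 of the 3 values shown sits. Compound 4 `COc1cccc(NC(=O)c2nnn(CC3CCN(C(=O)OC(C)(C)C)CC3)c2N)c1` differs from compound 2 by tert-butoxycarbonyl in place of hydrogen on an amine nitrogen in a ring. Within the data shown here, no measured step touches this amine nitrogen; the measured steps exchange the whole ring, so they give no direct guide, and from a limit any movement can only be upward or nil. Compound 4 is expected to give 2 mL.min-1.g-1 (range 0.5 mL.min-1.g-1 to 8 mL.min-1.g-1), an expected step of an at least 4.0-fold higher number from compound 2 to compound 4 (0.60 log units; beyond the scatter).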

Compound 4, intrinsic clearance in microsomes: 10 mL.min-1.g-1
Estimate against measurement, compound 4: 5.0-fold (0.70 log units) below; the measured number lies above the stated range.
By their numbers in this assay, from the lowest: compounds 1 and 3 (each within the scatter of the next); then compound 4. At a limit, below all of these: compound 2.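

On the amine nitrogen of the ring, a single substitution moves the number in this assay by a large step: tert-butoxycarbonyl in place of hydrogen (an at least 20-fold higher number from compound 2 to compound 4 (1.30 log units; beyond the scatter)). Among these compounds, the earlier steps exchanged the whole ring, so this is the first reading at this nitrogen with the ring itself kept. Compound 2 is reported only as a limit, so the step gives a lower bound on the change: the limit of < 0.5 mL.min-1.g-1 in this assay, at which 1 of the 4 values shown sits.

Open, going by these compounds, is whether a methyl or an acetyl group on this nitrogen stays close to compound 2 or moves toward compound 4. On these data alone, it also remains open whether the carbonyl or the tert-butyl part carries the step.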